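The source may report more compounds than this note shows. Statements on the series, on what has been measured and on what is new or still open speak of the compounds shown alone.

Compound 1 `Cc1cc(C)c(S(=O)(=O)N2CCC(N3CCC(O)CC3)CC2)c(C)c1` is the reference point of this small set. In a functional assay on DLD-1 cells (Homo sapiens) for antiproliferative activity, read by CellTiter-Glo, with a stated time of 72 h (a higher number here means a weaker inhibitor, a lower number a stronger inhibitor), compound 1 gives 106 nM, the lowest of the two numbers recorded. Compound 2 `CC1CCN(C2CCN(S(=O)(=O)c3cccc4cnccc34)CC2)CC1` in this assay gives 225 nM, a higher number than that of compound 1 and a difference beyond the usual scatter. For the measured compounds named here, compound 3 `CC1CCN(C2CCN(S(=O)(=O)c3nccn3C)CC2)CC1` is recorded only as a limit in this assay, with > 5000 nM reported rather than a number; it is the one value among the three that sits at the limit of > 5000 nM in this assay, at which 1 of the 3 values shown sits.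

Compound 4 `Cc1cc(C)c(S(=O)(=O)N2CCC(c3ccccc3)CC2)c(C)c1` has not yet been measured in this assay. It differs from compound 1 in a single place: phenyl in place of 4-hydroxypiperidin-1-yl on a saturated ring carbon. The 4-hydroxypiperidin-1-yl group, with its hydrogen-bond donor and two acceptors, is exchanged for a phenyl ring that carries neither. Going by the values given here, no measured pair in the set isolates this kind of change, so the size of the step can only be judged from the structures. The shared core of compound 1 is kept intact.

For compound 4 the expectation is a clearly weaker result in this assay, a step of a 14-fold higher number from compound 1 to compound 4 (1.15 log units; beyond the scatter) larger than the usual scatter. Compound 4 is thus estimated at 1500 nM, with a plausible range from 300 nM to 6000 nM.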

Compound 4, half-maximal inhibitory concentration: > 5000 nM
Compound 4: only a limit was reported; the forecaster's own chance of this, stated with the estimate: 25%; middle value at least 3.3-fold (0.52 log units) away from the limit.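

In this assay, for the compounds shown here, the exchange of 4-hydroxypiperidin-1-yl for phenyl on a saturated ring carbon gives an at least 47-fold higher number from compound 1 to compound 4 (1.67 log units; beyond the scatter), the first single-place comparison in this set. It shows that this place is not indifferent to the group it carries: with the shared core of compound 1 kept intact, a phenyl ring of carbon only, with no hydrogen-bond donor or acceptor, does not preserve the activity of compound 1. Compound 4 is reported only as a limit and not as a number, so the step has a floor but no known full size, and compound 4 joins the other value held at that limit: the limit of > 5000 nM in this assay, at which 2 of the 4 values shown sit.

The pair does not separate the parts of the departing group, since the ring nitrogen, the hydroxyl and the non-aromatic ring all leave together, and phenyl brings an aromatic ring in their place. Whether a plain piperidin-1-yl, a cyclohexyl ring carrying a hydroxyl, or a small open-chain amine such as dimethylamino would hold the activity at this place remains open in the compounds shown.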